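A Bromine for a Methoxy Group on the Aryl Ketone

The source may report more compounds than this note shows. Statements on the series, on what has been measured and on what is new or still open speak of the compounds shown alone.

Of the compounds shown here, two have been measured in a functional assay on A549 cells (Homo sapiens) for cytotoxicity, read by MTT assay, with a stated time of 48 h; a lower number here means a stronger inhibitor, a higher number a weaker inhibitor. Compound 1 `COc1cc(-c2nnc3n2NC(c2cccs2)C(C(=O)c2ccc(F)cc2)S3)cc(OC)c1OC` gives 45000 nM. Compound 2 `COc1ccc(C(=O)C2Sc3nnc(-c4cc(OC)c(OC)c(OC)c4)n3NC2c2ccco2)cc1` reaches only the limit > 100000 nM, which is a limit of this assay and not a number; it therefore stands at the limit of > 100000 nM in this assay, at which 1 of the 2 values shown sits. Compound 3 `COc1cc(-c2nnc3n2NC(c2ccco2)C(C(=O)c2cccc(Br)c2)S3)cc(OC)c1OC` differs from compound 2 by 3-bromophenyl in place of 4-methoxyphenyl on a carbonyl carbon. With no measured step to lean on, and with compound 1 giving 45000 nM as the only number, the change is expected to move potency little beyond the scatter, so compound 3 is estimated at 80000 nM, between 30000 nM and 300000 nM, a step of an at least 1.2-fold lower number from compound 2 to compound 3 (0.09 log units; that floor lies within the scatter) that is expected rather than shown.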

Compound 3, half-maximal inhibitory concentration: 36900 nM
Compound 3: middle estimate off by 2.2-fold (0.34 log units), on the high side, within the range that was stated.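

Placing 3-bromophenyl for 4-methoxyphenyl on a carbonyl carbon gives the first readable step at this position in this assay, and the printed step is an at least 2.7-fold lower number from compound 2 to compound 3 (0.43 log units; beyond the scatter). The aryl ketone is therefore a place where a single change moves the read-out beyond the scatter. The full size of the step cannot be read, since compound 2 stands at a limit of the assay and not at a number: the limit of > 100000 nM in this assay, at which 1 of the 3 values shown sits.

The compounds shown leave open whether the bromine, its ring position or the loss of the methoxy group carries the step. As far as these compounds go, how an amine or a carboxylic acid on this aryl ring would read also stays open.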